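Replacing benzyloxy with 3,4-difluorophenyl on a shared core

The source may hold more compounds than are shown below. What is called first, only, known or untested is meant among the compounds shown, and "the series" means these compounds.

In a physicochemical assay for solubility (a higher number here means a more soluble compound, a lower number a less soluble compound), compound 1 `CC(C)Oc1ccc(S(C)(=O)=O)cc1C(=O)N1Cc2cc(C(F)(F)F)cnc2C1` gives 114 ug/mL and compound 2 `CS(=O)(=O)c1ccc(OCc2ccccc2)c(C(=O)N2Cc3cc(C(F)(F)F)cnc3C2)c1` gives 72 ug/mL. Among the compounds with values here, the only measured step is a 1.6-fold lower number from compound 1 to compound 2 (0.20 log units; within the scatter), so compound 2 cannot be told apart from compound 1 on these numbers.

Compound 3 `CS(=O)(=O)c1ccc(-c2ccc(F)c(F)c2)c(C(=O)N2Cc3cc(C(F)(F)F)cnc3C2)c1` has not yet been measured. Its structure departs from compound 2 on an aromatic carbon, para to a methylsulfonyl group: 3,4-difluorophenyl in place of benzyloxy on an aromatic carbon. The measured step swaps isopropyl for benzyl on an oxygen and keeps that oxygen, so it bears on this change only loosely. Within the data shown here, no measured compound shows what happens when the oxygen goes or fluorine arrives. Among the measured compounds shown here, with a 1.6-fold lower number from compound 1 to compound 2 (0.20 log units; within the scatter) as the only guide, no change beyond the scatter is expected in this assay. The estimated step is a 1.4-fold lower number from compound 2 to compound 3 (0.16 log units; within the scatter). Compound 3 is expected to give about 50 ug/mL, within an estimated range of 15 ug/mL to 140 ug/mL.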

Compound 3, solubility: 42 ug/mL
The estimate for compound 3 lay 1.2-fold (0.08 log units) above the measured number; the range from low to high includes it.
By their numbers in this assay, from the lowest: compounds 3, 2 and 1 (each within the scatter of the next, the first and the last beyond it).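

In this assay the directly attached 3,4-difluorophenyl, set against benzyloxy on this aromatic carbon, gives a 1.7-fold lower number from compound 2 to compound 3 (0.23 log units; within the scatter) and so cannot be told apart from it. Set against isopropoxy on the same carbon, the ring gives a 2.7-fold lower number from compound 1 to compound 3 (0.43 log units; beyond the scatter) and this is the first step at this position to pass the scatter, though only modestly. Nothing measured here offers an explanation for that step.

Still open, going by these compounds, is whether the step goes with losing the oxygen or with gaining the two fluorines, which a plain phenyl or a 3,4-difluorobenzyloxy group on this carbon would help to separate. Also open, on these data alone, is how an amine or a carboxylic acid at this position would read in this assay against these three compounds.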